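This account rests on a few compounds, and the source may have more. Where it says the series, first, only, none or still open, it means among the compounds named here.

Within the data shown here, compound 1 `COc1n[nH]c2ncc(-c3cn(-c4c(F)ccc(NS(=O)(=O)c5cccc(Cl)c5)c4F)nn3)cc12` gives 1.9 nM in an assay on Sf9 cells for inhibition of mitogen-activated protein kinase kinase kinase 20 (Homo sapiens), read by ADP-Glo, with a stated time of 30 min (a lower number here means a stronger inhibitor, a higher number a weaker inhibitor), the lowest of the three numbers so far. Compound 3 `COc1n[nH]c2ncc(-c3cn(-c4cc(NS(=O)(=O)c5cccc(Cl)c5)ccc4F)nn3)cc12` gives 5.7 nM, and compound 2 `Nc1ncc(-c2cn(-c3c(F)ccc(NS(=O)(=O)c4cccc(Cl)c4)c3F)nn2)cn1` gives 8.9 nM, so both measured steps, a 3.0-fold higher number from compound 1 to compound 3 (0.48 log units; beyond the scatter) and a 4.7-fold higher number from compound 1 to compound 2 (0.67 log units; beyond the scatter), move away from compound 1 and lie beyond the scatter. Compound 4 `COc1n[nH]c2ncc(-c3cn(-c4c(F)ccc(NS(=O)(=O)c5cccc(C(C)C)c5)c4F)nn3)cc12` differs from compound 1 in a different way: isopropyl in place of chloro on an aromatic carbon. Neither measured step touches this part of the molecule, so neither bears directly on the change; they only show that single changes here have shifted the number by modest amounts. The step from compound 1 to compound 4 is therefore expected to be small, a 2.1-fold higher number from compound 1 to compound 4 (0.32 log units; beyond the scatter), and compound 4 is estimated at 4 nM, between 1.5 nM and 15 nM.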

Compound 4, half-maximal inhibitory concentration: 6.9 nM
Beside the measured number, compound 4's estimate is 1.7-fold (0.24 log units) below it; the measured number falls inside the stated range.
By their numbers in this assay, from the lowest: compound 1; then compounds 3, 4 and 2 (each within the scatter of the next).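

Among these compounds, as the 3-chlorophenyl becomes 3-isopropylphenyl, there is a 3.6-fold higher number from compound 1 to compound 4 (0.56 log units; beyond the scatter), so this position, untouched by the earlier steps, does respond to the group it carries. Chloro gives the lower number of the two, yet isopropyl is accepted here, with compound 4 still at 6.9 nM. Nothing measured here explains this step.

The compounds shown leave open whether a methyl, a methoxy group or an amine at this place would match or beat chloro. From the compounds shown here alone, whether isopropyl would shift the number similarly on compound 2 or compound 3 also remains open.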